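Swapping an aryl for a benzyl on a thiosemicarbazone

The source may report more compounds than this note shows. Statements on the series, on what has been measured and on what is new or still open speak of the compounds shown alone.

Compound 1 `CN(C)C(=S)N/N=C/c1ccc2ccccc2n1`, in a functional assay on SGC-7901 cells (Homo sapiens) for antiproliferative activity, read by sulforhodamine B assay, with a stated time of 72 h (a lower number here means a stronger inhibitor, a higher number a weaker inhibitor), gives 30 nM. Compound 2 `FC(F)(F)c1ccccc1NC(=S)N/N=C/c1ccc2ccccc2n1` gives 20700 nM in this assay. Compound 3 `Fc1ccccc1NC(=S)N/N=C/c1ccc2ccccc2n1` reaches only the assay's limit, > 100000 nM, not a number. The step of an at least 4.8-fold higher number from compound 2 to compound 3 (0.68 log units; beyond the scatter) is therefore known only as a lower bound, since compound 3 sits at the limit of > 100000 nM in this assay, at which 1 of the 3 values shown sits. Compound 4 `S=C(NCc1ccccc1)N/N=C/c1ccc2ccccc2n1` differs from compound 3 by benzyl in place of 2-fluorophenyl on an amide-type nitrogen. Within the data shown here, no measured step covers this change: compound 1 carries two methyl groups instead of an aryl, and compound 2 only changes the aryl's substituent. Compound 4 is estimated at 8000 nM, between 800 nM and 80000 nM, which means an expected step of an at least 12-fold lower number from compound 3 to compound 4 (1.09 log units; beyond the scatter) towards stronger inhibition, with wide uncertainty.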

Compound 4, half-maximal inhibitory concentration: 53700 nM
For compound 4 the middle estimate is 6.7-fold (0.83 log units) below the measured one; low and high end bracket the measured number.
By their numbers in this assay, from the lowest: compound 1; then compound 2; then compound 4. At a limit, above all of these: compound 3.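

On this amide-type nitrogen, benzyl gives a measured number in this assay, where 2-fluorophenyl gave only a limit. The change amounts to an at least 1.8-fold lower number from compound 3 to compound 4 (0.27 log units; that floor lies within the scatter), so the gain may be larger, but its floor alone does not separate the two groups. Compound 3 holds a limit and not a number, so the true size of the step stays unknown: the limit of > 100000 nM in this assay, at which 1 of the 4 values shown sits.

Still open, on these data alone, is whether a longer chain such as phenethyl, or a plain phenyl, on this nitrogen would come closer to compound 1 at 30 nM.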